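A few compounds are considered here, and "the series" means these few. Any claim that something is new, unique, unknown or untested is made for them only; others in the source may bear on it.

Compound 1 `COc1ccc(C(=O)/C=C/c2cc(OC)c(OC)c(OC)c2)c2c1C=CC(C)(C)O2` — in a functional assay on HT-29 cells (Homo sapiens) for antiproliferative activity, read by MTT assay, with a stated time of 24 h (on this read-out lower numbers stand for stronger inhibition and higher numbers for weaker inhibition), compound 1 gives > 10000 nM
Compound 2 `COc1ccc(C(=O)/C=C/c2ccc(Br)cc2)c2c1C=CC(C)(C)O2` — in this assay compound 2 gives > 10000 nM

For compound 2 the value > 10000 nM is a limit of the assay, not a number. For compound 1 the value > 10000 nM is likewise a limit. Compound 2 therefore stands at the limit of > 10000 nM in this assay, at which 2 of the 2 values shown sit, alongside compound 1, and no order between the two can be read from these values.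

Compound 3 `COc1ccc(C(=O)/C=C/c2ccc([N+](=O)[O-])cc2)c2c1C=CC(C)(C)O2` has not yet been measured. It differs from compound 2 in one place: nitro in place of bromo on an aromatic carbon. Among the measured compounds shown here, no step between two measured compounds is available here, so the size of this change cannot be taken from measured data. Given that both compound 1 and compound 2 sit at the limit (the limit of > 10000 nM in this assay, at which 2 of the 2 values shown sit), the expectation for compound 3 is no step beyond the scatter, most likely another limit rather than a number, which as a step reads a step that the limit leaves unreadable from compound 2 to compound 3. Compound 3 is accordingly estimated at 12000 nM, in a range from 3000 nM to 50000 nM.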

Compound 3, half-maximal inhibitory concentration: 3730 nM
For compound 3 the middle estimate is 3.2-fold (0.51 log units) above the measured one, within the range that was stated.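

In this assay, replacing bromo with nitro gives an at least 2.6-fold lower number from compound 2 to compound 3 (0.42 log units; beyond the scatter). Among the compounds shown here, this shows that the group on this aromatic carbon, para to a large group, can bring the read-out down from the limit to a readable number while the shared core stays the same, which the earlier compounds could not show because neither gave a number. The true size of the step remains unknown because the starting point is a limit and not a number, and this is still the usual position in the small set: the limit of > 10000 nM in this assay, at which 2 of the 3 values shown sit.

The compounds shown leave open whether another group at this position, such as an amine or a carboxylic acid, would lower the number further, match nitro or stay at the limit. With a single readable value, they also leave open whether nitro would give a comparable step on a differently substituted compound, so this one change cannot yet be called a pattern.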